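The source may hold more compounds than are shown below. What is called first, only, known or untested is meant among the compounds shown, and "the series" means these compounds.

Measured compounds:
Compound 1, `CCCc1cc(N)c2cc(NC(=O)/C=C/c3ccc(Cl)cc3)ccc2n1`: 6 nM
Compound 2, `CCCc1cc(OC)c2cc(NC(=O)/C=C/c3ccc(C(F)(F)F)cc3)ccc2n1`: 26 nM
Compound 3, `CCCc1cc(N2CCCC2)c2cc(NC(=O)/C=C/c3ccc(C(F)(F)F)cc3)ccc2n1`: 17 nM

In an assay on isolated protein for displacement of a labelled ligand from melanin-concentrating hormone receptor 1 (Homo sapiens) (on this read-out higher numbers stand for weaker inhibition and lower numbers for stronger inhibition), compound 1 gives the lowest of the three numbers, so among these compounds it is the strongest inhibitor; compound 3 comes nearest and compound 2 stands furthest away. Among the compounds with values here, the only step between two measured compounds that differ in one place is a 1.5-fold lower number from compound 2 to compound 3 (0.18 log units; within the scatter), and it concerns the group on the shared core rather than the phenyl ring at the far end of the molecule.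

Compound 4, `CCCc1cc(N)c2cc(NC(=O)/C=C/c3ccc(Cl)cc3Cl)ccc2n1`, has not yet been measured in this assay. It differs from compound 1 by chloro in place of hydrogen on an aromatic carbon. Within the data shown here, no measured pair shows the effect of a second chloro group on that phenyl ring, so no step bears directly on this change, and the single step that is known touches a different part of the molecule. Without such guidance the expectation is that the step of no change at the digits printed from compound 1 to compound 4 (within the scatter) stays within the scatter in this assay. Compound 4 is therefore estimated to give 6 nM, within a range from 2 nM to 20 nM.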

Compound 4, half-maximal inhibitory concentration: 6.6 nM
For compound 4 the middle estimate is 1.1-fold (0.04 log units) below the measured one; the range from low to high includes it.
By their numbers in this assay, from the lowest: compounds 1 and 4 (each within the scatter of the next); then compounds 3 and 2 (each within the scatter of the next).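

In this assay the second chlorine turns 4-chlorophenyl into 2,4-dichlorophenyl, and the swap gives a 1.1-fold higher number from compound 1 to compound 4 (0.04 log units; within the scatter) so the two numbers cannot be told apart. Within the data shown here, this place on the phenyl ring, ortho to a large group and meta to the first chloro group, therefore accepts a chlorine with no measurable penalty on this read-out, which the earlier compounds could not show because their only step concerned the group on the shared core. No measurement in hand offers a reason for this result.

The compounds shown leave open whether a fluoro group, a methyl group or a carboxylic acid at this same place would also leave the number where it is. They also leave open whether the second chlorine behaves alike when methoxy or pyrrolidin-1-yl replaces the amino group on the core.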